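The source may report more compounds than this note shows. Statements on the series, on what has been measured and on what is new or still open speak of the compounds shown alone.

Of the compounds shown here, three have been read so far in a functional assay for antagonist activity, with Cavia porcellus as the target (a higher number here means a weaker inhibitor, a lower number a stronger inhibitor), and only one gives a number. Compound 1 (`CN(C)CC#CCCC1SCCCS1`) gives > 10000000 nM there, which is a limit of the assay and not a number. Compound 2 (`C(#CCN1CCCCC1)CCC1SCCCS1`) gives > 10000000 nM there, again only a limit. Going by the values given here, compound 3 (`CN(CC#CCCC1(C(O)(c2ccccc2)c2ccccc2)SCCCS1)Cc1ccccc1`) gives 3170 nM and holds the only true number. Among the compounds with values here, the rest of the picture is the limit of > 10000000 nM in this assay, at which 2 of the 3 values shown sit, and no step between compounds differing in one place has been measured.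

Next in line is compound 4 (`CN(C)CC#CCCC1(C(O)(c2ccccc2)c2ccccc2)SCCCS1`). The change from compound 3 reads hydrogen in place of phenyl on a saturated chain carbon bound to an amine nitrogen and amounts to hydrogen in place of phenyl on a saturated chain carbon bound to an amine nitrogen, so that benzyl(methyl)amino becomes dimethylamino.

Within the data shown here, with no measured step to lean on, the expectation rests on compound 3 at 3170 nM alone, and no shift beyond the usual scatter is expected in this assay in either direction, although the uncertainty is wide. The estimated step of a 1.3-fold lower number from compound 3 to compound 4 (0.10 log units; within the scatter) is accordingly small. A reading that ends at the limit remains possible, as it did for compounds 1 and 2. Compound 4 is estimated at 2500 nM with an expected range from 300 nM to 20000 nM in this reading.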

Compound 4, antagonist equilibrium constant: 1810 nM
Compound 4: middle estimate off by 1.4-fold (0.14 log units), on the high side; low and high end bracket the measured number.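

Going by these compounds alone, the first measured step, a 1.8-fold lower number from compound 3 to compound 4 (0.24 log units; within the scatter), shows that in this assay hydrogen can stand in place of phenyl on a saturated chain carbon bound to an amine nitrogen without a shift beyond the usual scatter, so benzyl(methyl)amino and dimethylamino read alike on this core. The benzyl group is therefore not needed for a true number in this pair, and compound 4 joins compound 3 as the second compound with one. Compound 1 also carries dimethylamino, and it gives > 10000000 nM, which is a limit of the assay and not a number.

Any step to compound 1 or compound 2 cannot be read as a size, and the series has only one true step to work from: the limit of > 10000000 nM in this assay, at which 2 of the 4 values shown sit. Open at this position is how a diethylamino or a morpholine group would read on the core of compound 4, as is whether a primary amine in the same place would keep a true number in this assay or fall to the limit.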